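Aryl swap on the carbonyl carbon: compound 3 to compound 4

The compounds below may be only part of what the source reports. "The series", "measured", "known", "first", "only" and "open" are said of these compounds alone.

Three compounds of the shared core have numbers in a functional assay on NCI-H522 cells (Homo sapiens) for inhibition, read by sulforhodamine B assay, with a stated time of 48 h; on this read-out higher numbers stand for weaker inhibition of growth and lower numbers for stronger inhibition of growth. Compound 1 `COc1cc(-c2cc(/C=C/C(=O)c3ccc(N)cc3)[nH]n2)cc(OC)c1OC` gives 3990 nM. Compound 2 `COc1cc(-c2cc(/C=C/C(=O)c3ccc(Cl)c(Cl)c3)[nH]n2)cc(OC)c1OC` gives 3040 nM, and compound 3 `COc1ccc(C(=O)/C=C/c2cc(-c3cc(OC)c(OC)c(OC)c3)n[nH]2)cc1` gives 3200 nM. Compound 3 stands second highest of the three numbers; its nearest neighbour is compound 2 and its furthest is compound 1, and both gaps lie within the scatter. Compound 4 `COc1cc(-c2cc(/C=C/C(=O)c3ccc(F)c(F)c3)[nH]n2)cc(OC)c1OC` is not yet measured. It differs from compound 3 in one place: 3,4-difluorophenyl in place of 4-methoxyphenyl on a carbonyl carbon.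

Among the compounds with values here, the steps that bear on this change are those that exchange the aryl group on the carbonyl carbon. The step of a 1.1-fold higher number from compound 2 to compound 3 (0.02 log units; within the scatter) exchanges 3,4-dichlorophenyl for 4-methoxyphenyl; the step of a 1.3-fold lower number from compound 1 to compound 2 (0.12 log units; within the scatter) exchanges 4-aminophenyl for 3,4-dichlorophenyl. Both remain within the scatter, as does a 1.2-fold lower number from compound 1 to compound 3 (0.10 log units; within the scatter). No measured exchange on this carbon moves the number beyond the scatter, so the entering 3,4-difluorophenyl is expected to leave this assay about where compound 3 stands, with no step beyond the scatter in either direction. Compound 4 is therefore estimated at 3200 nM, with a range of 1400 nM to 7500 nM. The expected step is no change at the digits printed from compound 3 to compound 4 (within the scatter).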

Compound 4, concentration for total growth inhibition: 4480 nM
Compound 4: the middle estimate sits 1.4-fold (0.15 log units) below what was measured; the measured number falls inside the stated range.
By their numbers in this assay, from the lowest: compounds 2, 3, 1 and 4 (each within the scatter of the next).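

In this assay the exchange of 4-methoxyphenyl for 3,4-difluorophenyl on the carbonyl carbon gives a 1.4-fold higher number from compound 3 to compound 4 (0.15 log units; within the scatter) and so removes the hydrogen-bond acceptor counted for the leaving group without a step beyond the scatter. The exchange of 3,4-dichlorophenyl for 3,4-difluorophenyl gives a 1.5-fold higher number from compound 2 to compound 4 (0.17 log units; within the scatter) and the exchange of 4-aminophenyl for 3,4-difluorophenyl gives a 1.1-fold higher number from compound 1 to compound 4 (0.05 log units; within the scatter) so the fluorine pair also stays within the scatter of the chlorine pair and the amino group. All four aryl groups at this place now stand within the scatter of one another in every listed pair, and no measurement shown accounts for these small steps.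

The compounds shown carry only substituted phenyl groups on the carbonyl carbon, so it remains open whether any exchange at this place can move the number beyond the scatter. A pyridine ring, a carboxylic acid on the phenyl ring or a longer chain between the carbonyl carbon and the aryl group would test how far this tolerance extends.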